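This account rests on a few compounds, and the source may have more. Where it says the series, first, only, none or still open, it means among the compounds named here.

In an ADME assay on RD cells (Homo sapiens) for cytotoxicity, read by MTT assay, with a stated time of 3 days (on this read-out higher numbers stand for lower toxicity in this test and lower numbers for higher toxicity in this test), compound 1, `CC[C@H](CCn1cncn1)c1ccc(F)cc1`, gives 110 ug/mL. Compound 2, `CC[C@H](CCn1cncn1)c1ccc(Cl)cc1`, gives 57 ug/mL. Compound 3, `CC[C@@H](CCn1cncn1)c1ccc(Cl)cc1`, gives 55.3 ug/mL. Compound 3 holds the smallest of the three numbers, yet a 1.9-fold lower number from compound 1 to compound 2 (0.29 log units; within the scatter) and a 1.0-fold lower number from compound 2 to compound 3 (0.01 log units; within the scatter) are both within the scatter, so the three values are not separated; the second of these steps rests on (the fact that compounds 2 and 3 differ only in the configuration as drawn).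

Compound 4, `CC[C@@H](CCn1cncn1)c1ccc(C)cc1`, differs from compound 3 in that (methyl in place of chloro on an aromatic carbon). For the measured compounds named here, the only measured change at that aromatic carbon, a 1.9-fold lower number from compound 1 to compound 2 (0.29 log units; within the scatter), stayed within the scatter, and no measured step exchanges chloro for methyl. For compound 4 the expected step is therefore a 1.1-fold higher number from compound 3 to compound 4 (0.04 log units; within the scatter), within the scatter. Compound 4 is estimated at 60 ug/mL, in a range from 30 ug/mL to 120 ug/mL.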

Compound 4, half-maximal cytotoxic concentration: 79.4 ug/mL
Compound 4: middle estimate off by 1.3-fold (0.12 log units), on the low side; low and high end bracket the measured number.
By their numbers in this assay, from the lowest: compounds 3, 2, 4 and 1 (each within the scatter of the next).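

In this assay, the exchange of chloro for methyl on an aromatic carbon para to a large group gives a 1.4-fold higher number from compound 3 to compound 4 (0.16 log units; within the scatter). This brings the first group other than a halogen to this place, and the number still does not separate from that of the chloro compound. Nothing at hand bears on a cause for this step. The compounds shown leave open whether an amine or a carboxylic acid on this carbon would move the number beyond the scatter. They also leave open whether the drawn configuration matters with methyl here.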